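The compounds below may be only part of what the source reports. "The series", "measured", "known", "first", "only" and "open" are said of these compounds alone.

Measured so far:
- compound 1, `Fc1ccc(-c2nn3c(NC4CCCC4)cccc3c2-c2ccc3[nH]ccc3c2)cc1`: 20000 nM
- compound 2, `Fc1ccc(-c2nn3c(NC4CCCC4)cccc3c2-c2ccoc2)cc1`: "not determined" (no result reported)
- compound 3, `Nc1nccc(-c2c(-c3ccc(F)cc3)nn3c(NC4CCCC4)cccc23)n1`: 46000 nM

In an ADME assay on Vero cells (Chlorocebus sabaeus) for cytotoxicity (a lower number here means that less compound is tolerated, a higher number that more compound is tolerated), compound 3 gives 46000 nM, the higher of the two numbers available; compound 1 gives 20000 nM, and for compound 2 no number was reported. Going by the values given here, the one measured step, a 2.3-fold higher number from compound 1 to compound 3 (0.36 log units; beyond the scatter), swaps the group attached to the shared core and moves the number by a modest amount.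

Compound 4, `Fc1ccc(-c2nn3c(NC4CCCC4)cccc3c2-c2cc[nH]n2)cc1`, differs from compound 3 in the same position: 1H-pyrazol-3-yl in place of 2-aminopyrimidin-4-yl on an aromatic carbon. Among the compounds with values here, no measured step covers this exact swap, so the only guide is the step from compound 1 to compound 3, which shows that exchanging this aromatic group shifts this assay modestly at most. A small change in either direction, or none beyond the scatter, is therefore expected, and the estimate leans slightly downward toward the number seen for compound 1. Compound 4 is expected to give about 30000 nM, with a likely range from 12000 nM to 80000 nM. This corresponds to an expected step of a 1.5-fold lower number from compound 3 to compound 4 (0.19 log units; within the scatter).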

Compound 4, half-maximal cytotoxic concentration: 14000 nM
Compound 4: the middle estimate sits 2.1-fold (0.33 log units) above what was measured, within the range that was stated.
By their numbers in this assay, from the lowest: compounds 4 and 1 (each within the scatter of the next); then compound 3.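

In this assay the position on the shared core now has a second step: 1H-pyrazol-3-yl in place of 2-aminopyrimidin-4-yl gives a 3.3-fold lower number from compound 3 to compound 4 (0.52 log units; beyond the scatter) and so takes back the gain seen earlier with 2-aminopyrimidin-4-yl. Set against 1H-indol-5-yl, the same group gives a 1.4-fold lower number from compound 1 to compound 4 (0.15 log units; within the scatter) and so cannot be told apart from it here, which leaves compound 3 alone at the top of the three compounds with a number. No measurement shown bears on why this is so.

Going by these compounds, it remains open whether the amine of 2-aminopyrimidin-4-yl matters or the six-membered ring itself, which a pyrimidine without the amine would help to separate. On these data alone, it is also open how a non-aromatic group at this position, such as a morpholine or a carboxylic acid, would behave.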